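Methyl Shift on the Benzyl Group of Compound 1

A few compounds are considered here, and "the series" means these few. Any claim that something is new, unique, unknown or untested is made for them only; others in the source may bear on it.

Compound 1 `CSCC[C@H](NC(=O)c1ccc(NCc2cncn2Cc2cccc(C)c2)cc1-c1ccccc1)C(=O)O` is the reference point of this series. In a functional assay on NIH3T3 cells (Mus musculus) (a higher number here means that more compound is needed for the effect, a lower number that less compound is needed), compound 1 gives > 10 uM, which is a limit of the assay rather than a number. Compound 2 `COC(=O)[C@H](CCSC)NC(=O)c1ccc(CNCc2cncn2Cc2ccc(C#N)cc2)cc1-c1ccccc1C` belongs to the same series. In this assay compound 2 gives > 10 uM, again a limit. Both measured values thus sit at the limit of > 10 uM in this assay, at which 2 of the 2 values shown sit. Within the data shown here, no step between two measured compounds is available, so nothing yet shows how a change on the benzyl group moves the read-out.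

Compound 3 `CSCC[C@H](NC(=O)c1ccc(NCc2cncn2Cc2ccccc2C)cc1-c1ccccc1)C(=O)O` is not yet measured. It differs from compound 1 in one place: 2-methylphenyl in place of 3-methylphenyl on a saturated chain carbon bound to an aromatic nitrogen. Because both measured values sit at the limit of > 10 uM in this assay, at which 2 of the 2 values shown sit, the expectation for compound 3 in this assay is a further limit or a value close to it, with no step beyond the scatter. The step from compound 1 to compound 3 is expected to be a step that the limit leaves unreadable from compound 1 to compound 3. Compound 3 is estimated at 15 uM, in a range from 5 uM to 50 uM.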

Compound 3, concentration for half-maximal effect: > 10 uM
Compound 3 was reported as a limit; the forecaster's own chance of this, stated with the estimate: 80%; the middle value is on the limit's open side.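

No step can be read between compound 1 and compound 3, since both are reported only as limits in this assay: the limit of > 10 uM in this assay, at which 3 of the 3 values shown sit.

The compounds shown leave open whether any change on the benzyl group gives a readable value in this assay.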